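Swapping the anilino aryl group: from nitro to fluoro

The source may hold more compounds than are shown below. What is called first, only, known or untested is meant among the compounds shown, and "the series" means these compounds.

Compound 2 `C=CC(=O)Nc1cccc(NC(=O)CSc2nc(Nc3cccc([N+](=O)[O-])c3)c3ccccc3n2)c1`: 46300 nM
Compound 1 `C=CC(=O)Nc1cccc(NC(=O)CSc2nc(Nc3ccccc3Cl)c3ccccc3n2)c1`: 14400 nM

For the measured compounds named here, in a functional assay on PC-3 cells (Homo sapiens) for inhibition, read by MTT assay, with a stated time of 72 h (a lower number here means a stronger inhibitor, a higher number a weaker inhibitor), compound 2 gives 46300 nM, the highest of the two numbers measured so far, while compound 1 gives 14400 nM. Going by the values given here, the one measured step, a 3.2-fold higher number from compound 1 to compound 2 (0.51 log units; beyond the scatter), shows that changing the aryl group on the nitrogen on the aromatic ring shifts the number beyond the scatter, though only modestly.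

Compound 3 `C=CC(=O)Nc1cccc(NC(=O)CSc2nc(Nc3ccc(F)cc3)c3ccccc3n2)c1` differs from compound 2 in that (4-fluorophenyl in place of 3-nitrophenyl on a nitrogen on an aromatic ring). Among the compounds with values here, no measured step covers this exact exchange; the step from compound 1 to compound 2 is the only guide, and it shows a halogen-bearing phenyl giving the lower number. Compound 3 is therefore expected to move back towards the number of compound 1, with the step of a 2.3-fold lower number from compound 2 to compound 3 (0.36 log units; beyond the scatter) anticipated in this assay. The estimate for compound 3 is 20000 nM, within 7000 nM to 60000 nM.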

Compound 3, half-maximal inhibitory concentration: 8240 nM
Beside the measured number, compound 3's estimate is 2.4-fold (0.39 log units) above it; low and high end bracket the measured number.
By their numbers in this assay, from the lowest: compounds 3 and 1 (each within the scatter of the next); then compound 2.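

In this assay, the exchange of 3-nitrophenyl for 4-fluorophenyl gives a 5.6-fold lower number from compound 2 to compound 3 (0.75 log units; beyond the scatter), so a second halogen-bearing phenyl group, alongside the 2-chlorophenyl of compound 1, now sits clearly apart from the 3-nitrophenyl of compound 2. The two halogen-bearing groups themselves cannot be told apart here, as the exchange gives a 1.7-fold lower number from compound 1 to compound 3 (0.24 log units; within the scatter). Among these three compounds, then, the 3-nitrophenyl group stands alone at the high end, and the choice between fluorine and chlorine, each at its own place on the phenyl ring, does not register. No supporting measurement bears on why the number moves with this exchange.

The compounds shown leave open whether the nitro group itself or its place on the ring sets the higher number. They also leave open how an unsubstituted phenyl, a methoxyphenyl or a carboxylic acid on the phenyl ring would read at this position.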